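Solubility Follow-Up for a Hydroxylated Side Chain

The compounds below may be only part of what the source reports. "The series", "measured", "known", "first", "only" and "open" are said of these compounds alone.

For the measured compounds named here, compound 1 `CC(=O)N1CCc2c(C)c3c(n2-c2ccc(C(N)=O)c(c2)N[C@@H](C)[C@H](C)C1)CC(C)(C)CC3=O` was tested in a physicochemical assay for solubility, at pH 7.4 (a lower number here means a less soluble compound, a higher number a more soluble compound), where compound 1 gives 38 ug/mL, the only plain number measured so far. Compound 2 `CC[C@H](N)C(=O)N1CCc2c(C)c3c(n2-c2ccc(C(N)=O)c(c2)N[C@@H](C)[C@H](C)C1)CC(C)(C)CC3=O` reached a limit of this assay at > 100 ug/mL. Going by the values given here, the one measured step, an at least 2.6-fold higher number from compound 1 to compound 2 (0.42 log units; beyond the scatter), is the only comparison available. Compound 3 `Cc1c2c(n3c1CCN(C(=O)[C@@H](O)C(C)C)C[C@@H](C)[C@H](C)Nc1cc-3ccc1C(N)=O)CC(C)(C)CC2=O` alters the same group of compound 1: 1-hydroxy-2-methylpropyl in place of methyl on a carbonyl carbon. A rise in this assay is therefore expected, though a smaller one than that measured step cannot be ruled out. The step expected is a 1.7-fold higher number from compound 1 to compound 3 (0.23 log units; within the scatter). Compound 3 is estimated at 65 ug/mL, with a likely range from 28 ug/mL to 150 ug/mL.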

Compound 3, solubility: 30 ug/mL
Compound 3: the middle estimate sits 2.2-fold (0.34 log units) above what was measured; the measured number falls inside the stated range.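

On this carbonyl carbon, 1-hydroxy-2-methylpropyl gives a 1.3-fold lower number from compound 1 to compound 3 (0.10 log units; within the scatter), so a longer chain carrying a hydroxyl does not by itself shift this assay. The 1-aminopropyl of compound 2 stands apart, with an at least 3.3-fold lower number from compound 2 to compound 3 (0.52 log units; beyond the scatter). That step rests on a limit of the assay, not on a plain number: the limit of > 100 ug/mL in this assay, at which 1 of the 3 values shown sits.

Still open, going by these compounds, is whether the amine or the shape of the chain accounts for that gap, since compound 2 and compound 3 differ in both. 1-Hydroxypropyl and 1-amino-2-methylpropyl on the same carbonyl carbon would separate the two.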